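The source may report more compounds than this note shows. Statements on the series, on what has been measured and on what is new or still open speak of the compounds shown alone.

In a functional assay on HCT-116 cells (Homo sapiens) for inhibition, read by colorimetric assay, with a stated time of 3 days (on this read-out higher numbers stand for weaker inhibition and lower numbers for stronger inhibition), compound 1 `O=C(CCCCCCNC(=O)C(O)(O)C(F)(F)F)Nc1ccccc1Br` gives 14500 nM, which stands at the top of the two numbers recorded, although compound 2 `COc1cc(NC(=O)CCCCCCNC(=O)C(O)(O)C(F)(F)F)cc(OC)c1OC` gives 14100 nM and the gap between the two lies within the scatter. Compound 3 `C/C(=N\O)C(=O)NCCCCCCC(=O)Nc1ccccc1` is recorded only as a limit, > 100000 nM, the data showing (the limit of > 100000 nM in this assay, at which 1 of the 3 values shown sits). Compound 4 `O=C(CCCCCCNC(=O)C(O)(O)C(F)(F)F)Nc1cccc(Br)c1` has not yet been measured; it holds the same atoms as compound 1 joined differently: 3-bromophenyl in place of 2-bromophenyl on an amide-type nitrogen. Going by the values given here, no step between measured compounds bears on this change, so nothing beyond the scatter is expected, and the anticipated shift is a 1.0-fold lower number from compound 1 to compound 4 (0.02 log units; within the scatter). Compound 4 is accordingly expected to give about 14000 nM, with a range from 5000 nM to 40000 nM.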

Compound 4, half-maximal inhibitory concentration: 3060 nM
For compound 4 the middle estimate is 4.6-fold (0.66 log units) above the measured one; measured number below the stated range.
By their numbers in this assay, from the lowest: compound 4; then compounds 2 and 1 (each within the scatter of the next). At a limit, above all of these: compound 3.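

With the atoms unchanged, 3-bromophenyl in place of 2-bromophenyl on an amide-type nitrogen gives, in this assay, a 4.7-fold lower number from compound 1 to compound 4 (0.68 log units; beyond the scatter). This shows that the read-out at this position responds to where the bromine stands on the phenyl ring, a modest but real effect that no earlier comparison could reveal. Nothing measured here explains the step. The compounds shown leave open whether 3-chlorophenyl on this nitrogen would behave like 3-bromophenyl, and whether the step would persist with a longer chain.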